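Swapping the distal aryl group on a quinoline-type core

The source may report more compounds than this note shows. Statements on the series, on what has been measured and on what is new or still open speak of the compounds shown alone.

Measured compounds:
compound 1 `COc1cccc(Oc2ccc3c(NCCCNCc4ccco4)ccnc3c2)c1` gives 9.28
compound 2 `COc1cccc(CNCCCNc2ccnc3cc(Cc4cccc(C(F)(F)F)c4)ccc23)c1O` gives 9.47
compound 3 `COc1ccc(F)cc1CNCCCNc1ccnc2cc(Cc3cccc(C(F)(F)F)c3)ccc12` gives 9.47

In a physicochemical assay for acid dissociation, compound 3 stands level with compound 2 at the digits shown, and the two together sit at the top of the three numbers; compound 1 lies somewhat lower, but that gap is within the scatter. Compound 4 `COc1ccc(F)cc1CNCCCNc1ccnc2cc(-c3cccc4ccccc34)ccc12` differs from compound 3 in one place: naphthalen-1-yl in place of 3-(trifluoromethyl)benzyl on an aromatic carbon. For the measured compounds named here, the only measured step, no change at the digits printed from compound 2 to compound 3 (within the scatter), changed a group bound to the chain nitrogen and left the read-out unchanged; it does not touch the aryl group altered here, so no measured step bears directly on this change. Since the change sits far from the chain amines, compound 4 is expected to show a number 0.02 log units lower from compound 3 to compound 4 (within the scatter), giving an estimated 9.45 with a range from 9.1 to 9.8.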

Compound 4, acid dissociation constant: 9.47
Compound 4: the middle estimate sits 0.02 log units below what was measured, and the stated range covers the measured number.
By their numbers in this assay, from the lowest: compounds 1, 2, 3 and 4 (each within the scatter of the next).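

In this assay, naphthalen-1-yl in place of 3-(trifluoromethyl)benzyl on this aromatic carbon of the shared core gives no change at the digits printed from compound 3 to compound 4 (within the scatter) and this is the only step shown at this position. An entering group with 2 six-membered aromatic rings of carbon only and no fluorine thus leaves the read-out level with that of a group containing one such ring and fluorine. No supporting measurement is available to explain this result. From the compounds shown here alone, whether an amine or a carboxylic acid on this aromatic carbon would also leave the read-out level stays open.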